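Swapping a hydroxyethyl tail for a methylphenyl ring

A few compounds are considered here, and "the series" means these few. Any claim that something is new, unique, unknown or untested is made for them only; others in the source may bear on it.

All compounds here share one core and differ only in the group attached to a saturated chain carbon bound to an aromatic nitrogen. Within the data shown here, compound 3 `Cc1cc(C)c(Oc2cc(Nc3ccc(C#N)cc3)ncc2C(=O)NCc2cn(CCCO)nn2)c(C)c1` carries a 2-hydroxyethyl group there; in an ADME assay on MT4 cells (Homo sapiens) for cytotoxicity, read by MTT assay, with a stated time of 5 days (on this read-out higher numbers stand for lower toxicity in this test and lower numbers for higher toxicity in this test), compound 3 gives 25200 nM, the only plain number among the three measured compounds. Compound 1 `Cc1cc(C)c(Oc2cc(Nc3ccc(C#N)cc3)ncc2C(=O)NCc2cn(Cc3ccccc3[N+](=O)[O-])nn2)c(C)c1` carries a 2-nitrophenyl group, and in this assay compound 1 reaches only a limit, > 212000 nM. Compound 2 `Cc1cc(C)c(Oc2cc(Nc3ccc(C#N)cc3)ncc2C(=O)NCc2cn(Cc3ccc([N+](=O)[O-])cc3)nn2)c(C)c1` carries a 4-nitrophenyl group, and for compound 2 this assay likewise reports a limit, >= 139000 nM.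

Compound 4 `Cc1cc(C)c(Oc2cc(Nc3ccc(C#N)cc3)ncc2C(=O)NCc2cn(Cc3ccccc3C)nn2)c(C)c1` makes the change (2-methylphenyl in place of 2-hydroxyethyl on a saturated chain carbon bound to an aromatic nitrogen). The measured steps that bear on it run the opposite way: an at least 8.4-fold lower number from compound 1 to compound 3 (0.92 log units; beyond the scatter) and an at least 5.5-fold lower number from compound 2 to compound 3 (0.74 log units; beyond the scatter), both beyond the scatter. Replacing the 2-hydroxyethyl group with an aromatic ring is therefore expected to push the number in this assay upward, toward the limits seen for compound 1 and compound 2. The expected step is a 6.0-fold higher number from compound 3 to compound 4 (0.77 log units; beyond the scatter), and compound 4 is estimated at 150000 nM, between 40000 nM and 300000 nM.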

Compound 4, half-maximal cytotoxic concentration: >= 164000 nM
Compound 4: a limit, no number; the forecaster's own chance of this, stated with the estimate: 60%; at least 1.0-fold (0.03 log units) between middle value and limit.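

In this assay, putting 2-methylphenyl in place of 2-hydroxyethyl gives an at least 6.5-fold higher number from compound 3 to compound 4 (0.81 log units; beyond the scatter), and a higher number here means lower toxicity in this test. The earlier rings, 2-nitrophenyl and 4-nitrophenyl, both carried a nitro group, whereas this ring carries only a methyl, so a nitro group is not needed for the number to rise. Compound 1, compound 2 and compound 4 all carry limits rather than numbers, and the steps among them cannot be read.

Still open, on these data alone, is whether the rise follows the ring itself or the loss of the hydroxyl, a question that a plain propyl chain at this position would help to separate. Also open, as far as these compounds go, is how an amine or a carboxylic acid on that chain would read in this assay.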